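The source may hold more compounds than are shown below. What is called first, only, known or untested is meant among the compounds shown, and "the series" means these compounds.

In a functional assay on a cell-free system (plasma) with sterol O-acyltransferase, Soat (Rattus norvegicus) as the target (on this read-out higher numbers stand for an effect only at larger amounts of compound and lower numbers for an effect already at smaller amounts), compound 3 `CSc1cc(C)nc(SC)c1NC(=O)N(Cc1ccccc1)Cc1cccc(-c2ccnn2C)c1` gives only a limit, < 1 mg/kg, so its place among the measured compounds is not fixed by a number. Compound 2 `CSc1cc(C)nc(SC)c1NC(=O)N(Cc1ccccc1)Cc1cccc(-c2cc[nH]n2)c1` gives 0.046 mg/kg in this assay; it carries 1H-pyrazol-3-yl where compound 3 carries 1-methyl-1H-pyrazol-5-yl. The step that the limit leaves unreadable from compound 2 to compound 3 cannot be read as a size, since the value of compound 3 sits at the limit of < 1 mg/kg in this assay, at which 1 of the 3 values shown sits. Compound 1 `O=C(Nc1c(F)cc(F)cc1F)N(Cc1ccc(-c2cccs2)cc1)C1CCCCCC1`, built on a different core, is also known only as a limit in this assay, > 1 mg/kg. That limit is the limit of > 1 mg/kg in this assay, at which 1 of the 3 values shown sits, and gives no number either.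

Compound 4 `CSc1cc(C)nc(SC)c1NC(=O)N(Cc1ccccc1)Cc1cccc(-c2cnn(C)c2)c1` differs from compound 3 by 1-methyl-1H-pyrazol-4-yl in place of 1-methyl-1H-pyrazol-5-yl on an aromatic carbon. The two compounds contain the same atoms, joined differently. Within the data shown here, no measured step bears directly on this change; the only neighbouring step, a step that the limit leaves unreadable from compound 2 to compound 3, is itself unreadable, and compound 1 shares no single change with compound 4. A step of no size beyond the scatter, or a small one in either direction, is therefore the expectation for a step that the limit leaves unreadable from compound 3 to compound 4. The estimate for compound 4 in this assay is 0.1 mg/kg, with a range from 0.02 mg/kg to 0.8 mg/kg.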

Compound 4, dose for half-maximal effect: > 0.1 mg/kg
Compound 4: only a limit was reported; the forecaster's own chance of this, stated with the estimate: 30%; the middle value sits exactly at the limit.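

Compound 4 is known only through a limit, not a number: the limit of > 0.1 mg/kg in this assay, at which 1 of the 4 values shown sits.

Even so, this limit gives the first readable size of change at this place, on an aromatic carbon of a six-membered aromatic ring of carbon only, meta to a large group. Putting 1-methyl-1H-pyrazol-4-yl in place of 1H-pyrazol-3-yl gives an at least 2.1-fold higher number from compound 2 to compound 4 (0.33 log units; beyond the scatter) in this assay, which means that more compound is needed for the same effect. The steps that involve compound 3 cannot be read, so the two methylated pyrazoles cannot be put in order.

Compound 4 differs from compound 2 both in the added methyl group and in the point at which the pyrazole is attached, and the shown compounds do not separate these two parts of the change. Also open, on these data alone, is whether 1H-pyrazol-4-yl, or a ring carrying an amine or a carboxylic acid at this place, would match compound 2 at 0.046 mg/kg.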